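This account rests on a few compounds, and the source may have more. Where it says the series, first, only, none or still open, it means among the compounds named here.

Measured so far in a functional assay on Huh-7 cells (Homo sapiens) for inhibition, read by MTT assay, with a stated time of 48 h; on this read-out higher numbers stand for weaker inhibition and lower numbers for stronger inhibition:
- compound 1 `COc1ccc2c(=O)c(/C=C/C(=O)NCc3cccc(F)c3)coc2c1` — 10100 nM
- compound 2 `COc1cccc(NC(=O)/C=C/c2coc3cc(OC)ccc3c2=O)c1` — 11100 nM

Going by the values given here, compound 2 stands at the highest of the two numbers, but its only neighbour is compound 1, and the step of a 1.1-fold higher number from compound 1 to compound 2 (0.04 log units; within the scatter) lies within the scatter, so the two are indistinguishable on this read-out. Both share the core of compound 1 and differ only in the group on the amide-type nitrogen.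

Compound 3 `COc1ccc2c(=O)c(/C=C/C(=O)Nc3ccccc3Cl)coc2c1` is not yet measured. Relative to compound 2 the change is 2-chlorophenyl in place of 3-methoxyphenyl on an amide-type nitrogen. Among the compounds with values here, the one measured step that bears on it, the exchange of the group on the amide-type nitrogen, gave a 1.1-fold higher number from compound 1 to compound 2 (0.04 log units; within the scatter), a step within the scatter. On that basis no movement beyond the scatter is expected for compound 3 in this assay, and the expected step is a 1.0-fold lower number from compound 2 to compound 3 (0.00 log units; within the scatter). Compound 3 is therefore estimated at 11000 nM, with a range of 5000 nM to 25000 nM.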

Compound 3, half-maximal inhibitory concentration: 58400 nM
For compound 3 the middle estimate is 5.3-fold (0.73 log units) below the measured one; measured number above the stated range.
By their numbers in this assay, from the lowest: compounds 1 and 2 (each within the scatter of the next); then compound 3.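

In this assay the group on the amide-type nitrogen now moves the read-out: 2-chlorophenyl in place of 3-methoxyphenyl gives a 5.3-fold higher number from compound 2 to compound 3 (0.72 log units; beyond the scatter) and 2-chlorophenyl in place of 3-fluorobenzyl gives a 5.8-fold higher number from compound 1 to compound 3 (0.76 log units; beyond the scatter) and both steps lie beyond the scatter. The earlier exchange at this place stayed within the scatter, so this position is not indifferent to its substituent, and compound 3 is weaker than both compound 1 and compound 2. Nothing measured here explains the weaker result.

Compound 3 changes both the substituent and its numbered ring position relative to compound 2, and these two changes cannot be separated with the compounds shown. As far as these compounds go, how an amine or a carboxylic acid on the phenyl ring, or a longer chain on the amide-type nitrogen, would affect the number remains open.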